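The source may report more compounds than this note shows. Statements on the series, on what has been measured and on what is new or still open speak of the compounds shown alone.

Compound 1 `COc1cc(N(Cc2nc3ccccc3[nH]2)S(=O)(=O)c2ccccc2Cl)cc(OC)c1OC` gives 19100 nM in a functional assay on MGC-803 cells (Homo sapiens) for inhibition, read by MTT assay, with a stated time of 48 h; on this read-out higher numbers stand for weaker inhibition and lower numbers for stronger inhibition.
Compound 2 `COc1cc(N(Cc2nc3ccccc3[nH]2)C(=O)c2ccc(F)cc2)cc(OC)c1OC` gives 23600 nM in this assay.

Within the data shown here, only two compounds have been measured, and compound 2 sits beside compound 1 with no separation that the assay can resolve: the step of a 1.2-fold higher number from compound 1 to compound 2 (0.09 log units; within the scatter) lies within the scatter. Compound 3 `COc1cc(N(Cc2nc3ccccc3[nH]2)C(=O)c2cccc(Cl)c2)cc(OC)c1OC` has not yet been tested. It differs from compound 2 by 3-chlorophenyl in place of 4-fluorophenyl on a carbonyl carbon, so the change is confined to the ring carried on the carbonyl carbon, with the same count of heavy atoms and the same absence of donors and acceptors on either side.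

Among the measured compounds shown here, no measured step touches this exchange. For the measured compounds named here, the one step available, from a (2-chlorophenyl)sulfonyl group to a (4-fluorophenyl)carbonyl group, replaced the whole substituent on the nitrogen and still produced no movement beyond the scatter, and it gives no reading on a halogen shift within the phenyl ring. The expectation for compound 3 in this assay is therefore a step of about a 1.1-fold lower number from compound 2 to compound 3 (0.03 log units; within the scatter), that is, none beyond the scatter. Compound 3 is estimated at 22000 nM, within a range from 8000 nM to 60000 nM.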

Compound 3, half-maximal inhibitory concentration: > 50000 nM
Compound 3 was reported as a limit; the forecaster's own chance of this, stated with the estimate: 10%; at least 2.2-fold (0.35 log units) between middle value and limit.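

In this assay compound 3 is reported only as a limit and not as a number: the limit of > 50000 nM in this assay, at which 1 of the 3 values shown sits. Even so, the ring on the carbonyl carbon proves to be a place where the read-out can move: 3-chlorophenyl in place of 4-fluorophenyl gives an at least 2.1-fold higher number from compound 2 to compound 3 (0.32 log units; beyond the scatter), whereas replacing the whole substituent on the nitrogen had given only a 1.2-fold higher number from compound 1 to compound 2 (0.09 log units; within the scatter). The change from (2-chlorophenyl)sulfonyl to (3-chlorophenyl)carbonyl likewise gives an at least 2.6-fold higher number from compound 1 to compound 3 (0.41 log units; beyond the scatter), so a carbonyl link does not by itself fix the value, and what is carried on that carbonyl carbon matters in this series.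

The exchange alters both the halogen and its place on the ring, and the compounds shown do not separate these two changes. On these data alone, the full size of the step also stays open, as does whether an amine or a carboxylic acid on the same ring would give a lower number than the halogen-bearing rings do.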